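The compounds below may be only part of what the source reports. "The series", "measured", "known", "first", "only" and "open" are said of these compounds alone.

Compound 1 `CCOC(=O)C12C(=O)OCC=C1COC2c1ccccc1`: in a functional assay on A549 cells (Homo sapiens) for cytotoxicity, read by MTT assay (a higher number here means a weaker inhibitor, a lower number a stronger inhibitor), compound 1 gives > 1000000 nM, which is a limit of the assay and not a number.
Compound 2 `CCOC(=O)C12C(=O)OCC=C1COC2c1ccccc1F`: in this assay compound 2 gives > 1000000 nM, again a limit of the assay.
Compound 3 `CCOC(=O)C12C(=O)OCC=C1COC2c1ccc(F)cc1`: in this assay compound 3 gives > 1000000 nM, also a limit of the assay.

Going by the values given here, compound 3 therefore stands nowhere distinct among the three: every value shown sits at the limit of > 1000000 nM in this assay, at which 3 of the 3 values shown sit, so no compound can be placed above or below another. Compound 4 `CCOC(=O)C12C(=O)OCC=C1COC2c1cccc(Cl)c1` carries the change (3-chlorophenyl in place of 4-fluorophenyl on a saturated ring carbon). The measured steps that come closest are the swaps on the same aromatic ring, a step that the two limits leave unreadable from compound 1 to compound 2, a step that the two limits leave unreadable from compound 1 to compound 3 and the direct exchange of one fluorophenyl for the other, a step that the two limits leave unreadable from compound 2 to compound 3; each of them is unreadable because both ends sit at the limit. Nothing in these numbers shows that a halogen on the phenyl ring, or its position, moves the value out of the range where the assay stops counting. The expected step from compound 3 to compound 4 is therefore a number no higher from compound 3 to compound 4 (the limit leaves the size open), meaning no change beyond the scatter. For compound 4 the estimate in this assay is 1000000 nM, within 300000 nM to 3000000 nM, most likely reported again as a limit rather than a number.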

Compound 4, half-maximal inhibitory concentration: 28400 nM
Compound 4: middle estimate off by 35-fold (1.55 log units), on the high side, and the stated range ends above it.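

The aryl group on the saturated ring carbon next to the ring oxygen can clearly move the result: in this assay, 3-chlorophenyl in place of 4-fluorophenyl gives an at least 35-fold lower number from compound 3 to compound 4 (1.54 log units; beyond the scatter), 3-chlorophenyl in place of 2-fluorophenyl gives an at least 35-fold lower number from compound 2 to compound 4 (1.54 log units; beyond the scatter), and 3-chlorophenyl in place of the unsubstituted phenyl gives an at least 35-fold lower number from compound 1 to compound 4 (1.54 log units; beyond the scatter). These sizes are only minimums because the other end of each step is a limit of the assay and not a number: the limit of > 1000000 nM in this assay, at which 3 of the 4 values shown sit. Compound 2 and compound 3 go against any rule that a halogen on the phenyl ring is enough for a measurable value, and the steps among the first three compounds cannot be read.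

The change from compound 3 to compound 4 alters both the halogen and its place on the ring, so the compounds shown do not tell which of the two matters; 3-fluorophenyl and 4-chlorophenyl would separate them. From the compounds shown here alone, whether a different group on the phenyl ring, such as methoxy, an amine or a carboxylic acid, would give a lower or higher number than compound 4 also stays open.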